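A Single Methyl Group Tested in Whole Mice

The compounds below may be only part of what the source reports. "The series", "measured", "known", "first", "only" and "open" are said of these compounds alone.

All three measured compounds were tested in a functional assay on the whole organism for antagonist activity, with Mus musculus as the target; on this read-out higher numbers stand for an effect only at larger amounts of compound and lower numbers for an effect already at smaller amounts. Compound 2 `CC(=O)N(C)CC#CCn1ccnc1` gives > 100 mg/kg, which is a limit of the assay rather than a number. Compound 1 `CC(=O)N(C)C(C)C#CCn1ccnc1` likewise gives > 100 mg/kg, again a limit. The two differ by methyl in place of hydrogen on a saturated chain carbon bound to an amide-type nitrogen and a triple-bonded carbon, and the step that the two limits leave unreadable from compound 2 to compound 1 cannot be sized because the limit of > 100 mg/kg in this assay, at which 2 of the 3 values shown sit, is where both values sit. Compound 3 `COC(=O)N(C)CC#CCN1CCCC1` gives > 10 mg/kg, also a limit; how its core differs from the core of compound 2 is not broken down here. Compound 4 `COC(=O)N(C)C(C)C#CCN1CCCC1` is compound 3 carrying the same change, (methyl in place of hydrogen on a saturated chain carbon bound to an amide-type nitrogen and a triple-bonded carbon). Since the limit of > 10 mg/kg in this assay, at which 1 of the 3 values shown sits, holds compound 3 and the earlier step stayed unreadable, compound 4 is expected to show the step that the limit leaves unreadable from compound 3 to compound 4. The estimate for compound 4 is 30 mg/kg, between 5 mg/kg and 300 mg/kg, most likely reported again only as a limit.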

Compound 4, dose for half-maximal effect: > 100 mg/kg
Compound 4: a limit, no number; the forecaster's own chance of this, stated with the estimate: 80%; at least 3.3-fold (0.52 log units) between middle value and limit.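

Compound 3 and compound 4 are both reported only as limits, and the step between them cannot be read. Whether methyl in place of hydrogen changes the dose needed in this assay at all stays open for the compounds shown.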